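The source may report more compounds than this note shows. Statements on the series, on what has been measured and on what is new or still open speak of the compounds shown alone.

Three compounds share one core and differ only in the group carried on a saturated chain carbon bound to an amide-type nitrogen. In an assay on isolated protein for binding affinity to Gonadotropin-releasing hormone receptor (Homo sapiens) (a higher number here means a weaker inhibitor, a lower number a stronger inhibitor), compound 1 `CCOC(=O)[C@H]1CC[C@H](CNC(=O)c2ccc(Cc3cc4c(cc3C)C(C)(C)CCC4(C)C)o2)CC1` gives 51 nM, compound 2 `Cc1cc2c(cc1Cc1ccc(C(=O)NCc3ccc(CN)cc3)o1)C(C)(C)CCC2(C)C` gives 140 nM, and compound 3 `Cc1cc2c(cc1Cc1ccc(C(=O)NCc3ccccc3)o1)C(C)(C)CCC2(C)C` gives 102 nM. Compound 3 stands second highest of these three numbers; its nearest is compound 2, with a 1.4-fold lower number from compound 2 to compound 3 (0.14 log units; within the scatter), and its furthest is compound 1, with a 2.0-fold higher number from compound 1 to compound 3 (0.30 log units; within the scatter). Compound 4 `Cc1cc2c(cc1Cc1ccc(C(=O)NCC3CCN(C(=N)N)CC3)o1)C(C)(C)CCC2(C)C` differs from compound 3 in that same place: a group of 9 heavy atoms (6 carbon, 3 nitrogen; one six-membered non-aromatic ring with 1 hetero atom) in place of a group of 6 heavy atoms (6 carbon; one six-membered aromatic ring of carbon only), on a saturated chain carbon bound to an amide-type nitrogen. The measured steps that bear on this change are the three exchanges made at this place, a 2.7-fold higher number from compound 1 to compound 2 (0.44 log units; beyond the scatter), a 2.0-fold higher number from compound 1 to compound 3 (0.30 log units; within the scatter) and a 1.4-fold lower number from compound 2 to compound 3 (0.14 log units; within the scatter), and none of them is large. Exchanges at this place have so far moved this assay little, so compound 4 is expected to show a step of a 1.1-fold higher number from compound 3 to compound 4 (0.03 log units; within the scatter), with no clear direction beyond the scatter. The estimate for compound 4 is 110 nM, within a range from 40 nM to 320 nM.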

Compound 4, inhibition constant: 220 nM
Compound 4: the middle estimate sits 2.0-fold (0.30 log units) below what was measured; the range from low to high includes it.
By their numbers in this assay, from the lowest: compounds 1, 3, 2 and 4 (each within the scatter of the next, the first and the last beyond it).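

In this assay, compound 4 gives the first exchange from the phenyl of compound 3 that goes beyond the scatter (a 2.2-fold higher number from compound 3 to compound 4 (0.33 log units; beyond the scatter)). Set against the 4-(aminomethyl)phenyl group, the new group stays within the scatter (a 1.6-fold higher number from compound 2 to compound 4 (0.20 log units; within the scatter)), while set against the 4-(ethoxycarbonyl)cyclohexyl group it gives the largest step yet seen at this place (a 4.3-fold higher number from compound 1 to compound 4 (0.63 log units; beyond the scatter)), so the place does respond to what it carries, though only modestly so far. Nothing measured here offers a reason for these steps.

Going by these compounds, the change in compound 4 swaps the ring and adds its nitrogens in one move, so the share of each in the step stays open. Also open, on these data alone, is how a simple amine on the same ring, or a carboxylic acid in place of the ethyl ester of compound 1, would compare.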